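Methyl to hydrogen on the ring oxygen: transferring one step

The source may report more compounds than this note shows. Statements on the series, on what has been measured and on what is new or still open speak of the compounds shown alone.

Compound 1 `COc1cc(-c2nn(-c3cccc(NC(=O)Nc4cc(C(F)(F)F)cc(C(F)(F)F)c4)c3)cc2-c2ccncc2)ccc1Cl` gives 144 nM in a functional assay on HOP-92 cells (Homo sapiens) for inhibition, read by sulforhodamine B assay, with a stated time of 48 h; on this read-out lower numbers stand for stronger inhibition of growth and higher numbers for weaker inhibition of growth. Compound 2 `COc1cc(-c2nn(-c3cccc(NC(=O)Nc4ccc(Cl)c(Cl)c4)c3)cc2-c2ccncc2)ccc1Cl` gives 151 nM in this assay; the two values lie within the scatter, and the difference between the two cores is not broken down here. Relative to compound 2, compound 3 `O=C(Nc1cccc(-n2cc(-c3ccncc3)c(-c3ccc(Cl)c(O)c3)n2)c1)Nc1ccc(Cl)c(Cl)c1` carries the change hydrogen in place of methyl on an oxygen on an aromatic ring and gives 679 nM in this assay, a step of a 4.5-fold higher number from compound 2 to compound 3 (0.65 log units; beyond the scatter). Compound 4 `O=C(Nc1cccc(-n2cc(-c3ccncc3)c(-c3ccc(Cl)c(O)c3)n2)c1)Nc1cc(C(F)(F)F)cc(C(F)(F)F)c1`, not yet measured, carries the same change relative to compound 1, (hydrogen in place of methyl on an oxygen on an aromatic ring), at a place described in identical terms. Among the compounds with values here, the step is expected to be of similar size, a 4.3-fold higher number from compound 1 to compound 4 (0.63 log units; beyond the scatter), resting on the single measured pair, a 4.5-fold higher number from compound 2 to compound 3 (0.65 log units; beyond the scatter). Within the data shown here, compound 4 is therefore expected near 620 nM, between 300 nM and 1300 nM, the range widened since only one example of the change is available.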

Compound 4, concentration for 50% growth inhibition: 344 nM
For compound 4 the middle estimate is 1.8-fold (0.26 log units) above the measured one; the range from low to high includes it.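

Hydrogen in place of methyl on the ring oxygen moves the number the same way on both cores in this assay, with the new step of a 2.4-fold higher number from compound 1 to compound 4 (0.38 log units; beyond the scatter) on the core of compound 1. The two steps do not differ beyond what repeated measurement allows: the same change on two cores in this assay, a 4.5-fold higher number (0.65 log units; beyond the scatter) from compound 2 to compound 3 and a 2.4-fold higher number (0.38 log units; beyond the scatter) from compound 1 to compound 4, 1.9-fold (0.27 log units) apart, within the scatter of two such steps. This supports carrying the direction of the change from one core to the other in this series, but two pairs do not fix a general size for the step, nor do they explain why the step occurs.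

Still open, going by these compounds, is how an ethyl group or a longer chain on that oxygen would compare with methyl and hydrogen. Also open, on these data alone, is whether an amine in place of the hydroxy would behave like either.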